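A few compounds are considered here, and "the series" means these few. Any claim that something is new, unique, unknown or untested is made for them only; others in the source may bear on it.

In a functional assay on HCT-116 cells (Homo sapiens) for antiproliferative activity, with a stated time of 72 h (a lower number here means a stronger inhibitor, a higher number a weaker inhibitor), compound 3 `COc1ccc(-c2cc([C@@H]3O[C@H](CO)[C@@H](O)[C@H]3O)n3ncnc(N)c23)cc1` gives 47100 nM, the higher of the two exact numbers, while compound 1 `CCCC#Cc1cc([C@@H]2O[C@H](CO)[C@@H](O)[C@H]2O)n2ncnc(N)c12` gives 200 nM. Compound 2 `Nc1ncnn2c([C@@H]3O[C@H](CO)[C@@H](O)[C@H]3O)cc(C#Cc3ccc(F)cc3)c12` reaches only a limit of the assay, > 100000 nM. Compound 4 `Nc1ncnn2c([C@@H]3O[C@H](CO)[C@@H](O)[C@H]3O)cc(-c3ccsc3)c12` has thiophen-3-yl in place of 4-methoxyphenyl on an aromatic carbon. For the measured compounds named here, two measured steps bear on this change. The large one, a 240-fold higher number from compound 1 to compound 3 (2.37 log units; beyond the scatter), replaces pent-1-yn-1-yl with 4-methoxyphenyl at this same place, and the other, an at least 2.1-fold lower number from compound 2 to compound 3 (0.32 log units; beyond the scatter), joins two weak compounds. Since compound 4 keeps an aromatic ring there, only a moderate gain is expected, not a full return to the level of compound 1. The expected step is a 7.9-fold lower number from compound 3 to compound 4 (0.89 log units; beyond the scatter), toward a lower number. For compound 4 the estimated value is 6000 nM, within a range of 500 nM to 60000 nM.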

Compound 4, half-maximal inhibitory concentration: 45200 nM
Compound 4: middle estimate off by 7.5-fold (0.88 log units), on the low side; the measured number falls inside the stated range.
By their numbers in this assay, from the lowest: compound 1; then compounds 4 and 3 (each within the scatter of the next). At a limit, above all of these: compound 2.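

At this aromatic carbon, thiophen-3-yl and 4-methoxyphenyl cannot be told apart in this assay, with a 1.0-fold lower number from compound 3 to compound 4 (0.02 log units; within the scatter), so two different aromatic rings land at the same level. Pent-1-yn-1-yl stays far ahead of the thiophene, with a 230-fold higher number from compound 1 to compound 4 (2.35 log units; beyond the scatter). The step of an at least 2.2-fold lower number from compound 2 to compound 4 (0.34 log units; beyond the scatter) rests on the limit of compound 2 and not on a number: the limit of > 100000 nM in this assay, at which 1 of the 4 values shown sits.

The compounds shown leave open whether the low number of compound 1 needs the triple bond or mainly its propyl end. A plain pentyl chain, or an amine at the end of the alkyne chain, could separate the two.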